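A methoxy added to the aryl ether of compound 2

The compounds below may be only part of what the source reports. "The series", "measured", "known", "first", "only" and "open" are said of these compounds alone.

Of the compounds shown here, three have been measured in an assay on WI 38 cells for displacement of a labelled ligand from B1 bradykinin receptor (Homo sapiens); on this read-out lower numbers stand for stronger inhibition and higher numbers for weaker inhibition. For the measured compounds named here, compound 1 `O=C(O)CCNC(=O)CN(CCOc1ccc2c(c1)CCC2)S(=O)(=O)c1ccc(Cl)cc1Cl` gives 410 nM, and compound 3 `COCCCNC(=O)CN(CCOc1ccc2c(c1)CCC2)S(=O)(=O)c1ccc(Cl)cc1Cl` gives 1210 nM; the only single-point step among them, a 3.0-fold higher number from compound 1 to compound 3 (0.47 log units; beyond the scatter), concerns the amide side chain of their shared core. Compound 2 `CC(C)COc1ccc(CN(CC(=O)NCc2ccccc2Cl)S(=O)(=O)c2ccc(CN3CCN(C)CC3)cc2)cc1`, built on a different core, gives 113 nM in this assay and so stands lowest of the three numbers, below compound 1 and further still below compound 3.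

Compound 4 `COc1cc(CN(CC(=O)NCc2ccccc2Cl)S(=O)(=O)c2ccc(CN3CCN(C)CC3)cc2)ccc1OCC(C)C` has not yet been measured in this assay. It differs from compound 2 in one place, (methoxy in place of hydrogen on an aromatic carbon), on an aromatic carbon of a six-membered aromatic ring of carbon only, ortho to an isobutoxy group and meta to a large group.

Going by the values given here, no measured step touches this ring or this kind of substitution; the step from compound 1 to compound 3 sits on another part of another core and gives no guide here. With nothing to point either way, compound 4 is expected to stay close to compound 2, with a step of a 1.0-fold lower number from compound 2 to compound 4 (0.01 log units; within the scatter) that is not expected to go beyond the scatter. Compound 4 is therefore estimated at 110 nM in this assay, within a range from 35 nM to 350 nM.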

Compound 4, inhibition constant: 11 nM
For compound 4 the middle estimate is 10-fold (1.00 log units) above the measured one; measured number outside the range, below it.
By their numbers in this assay, from the lowest: compound 4; then compound 2; then compound 1; then compound 3.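

In this assay the methoxy in place of hydrogen gives a 10-fold lower number from compound 2 to compound 4 (1.01 log units; beyond the scatter) and so counts as a large step, well beyond the scatter. For the compounds shown here, this is the first change measured on this ring, and it shows that this aromatic carbon, ortho to an isobutoxy group and meta to a large group, is far from indifferent to substitution: an uncharged group of only 2 heavy atoms, with no ring and no hydrogen-bond donor, is enough to shift the binding number this much. Going by these compounds alone, the only earlier step concerned the amide side chain of a different core and said nothing about this aromatic carbon, and no measurement offered here accounts for the size of the new step.

One pair cannot show whether the gain belongs to methoxy itself or would also come with an ethoxy group, a hydroxy group or a fluorine atom on the same aromatic carbon. As far as these compounds go, it also remains open whether a methoxy group would give a similar step on the core of compound 1, or with a group other than isobutoxy on the neighbouring oxygen.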